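Swapping a dichlorophenyl for a chloronitrophenyl on a dienone

The source may hold more compounds than are shown below. What is called first, only, known or untested is meant among the compounds shown, and "the series" means these compounds.

Compound 2 `O=C(/C=C/c1ccc(Oc2ncnc3ccc(Cl)cc23)cc1)/C=C/c1c(Cl)cccc1Cl` gives 9300 nM in a functional assay on PC-3 cells (Homo sapiens) for inhibition, read by MTT assay, with a stated time of 72 h; on this read-out lower numbers stand for stronger inhibition and higher numbers for weaker inhibition. Among the three measured compounds this places compound 2 second highest; compound 3 `O=C(/C=C/c1ccc(Cl)c([N+](=O)[O-])c1)/C=C/c1ccccc1Oc1ncnc2ccc(Cl)cc12` gives 9760 nM in this assay, a number within the scatter of that of compound 2, while compound 1 `O=C(/C=C/c1ccc(Oc2ncnc3ccc(Cl)cc23)cc1)/C=C/c1cc([N+](=O)[O-])ccc1Cl` gives 3150 nM in this assay, the furthest of the three from compound 2. The change under consideration, (4-chloro-3-nitrophenyl in place of 2,6-dichlorophenyl on a double-bonded chain carbon bound to a double-bonded chain carbon), produces compound 4 `O=C(/C=C/c1ccc(Oc2ncnc3ccc(Cl)cc23)cc1)/C=C/c1ccc(Cl)c([N+](=O)[O-])c1`. Going by the values given here, one measured step bears on it directly, though in the opposite direction: a 3.0-fold higher number from compound 1 to compound 2 (0.47 log units; beyond the scatter), a modest shift beyond the scatter when a chloronitrophenyl was exchanged for the dichlorophenyl. Compound 4 carries a chloronitrophenyl with a different arrangement than compound 1, so the reversal is not exact. A modest step toward a lower number is therefore expected, a 2.3-fold lower number from compound 2 to compound 4 (0.37 log units; beyond the scatter), and compound 4 is estimated at 4000 nM in this assay, with a range from 1500 nM to 12000 nM.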

Compound 4, half-maximal inhibitory concentration: 11800 nM
Estimate against measurement, compound 4: 3.0-fold (0.47 log units) below, within the range that was stated.
By their numbers in this assay, from the lowest: compound 1; then compounds 2, 3 and 4 (each within the scatter of the next).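

In this assay, a nitro group in the ring does not by itself set a compound apart from the dichlorophenyl analogue, with a 1.3-fold higher number from compound 2 to compound 4 (0.10 log units; within the scatter) on the exchange of 2,6-dichlorophenyl for 4-chloro-3-nitrophenyl. The two chloronitrophenyl groups do differ from each other at this place, with a 3.7-fold higher number from compound 1 to compound 4 (0.57 log units; beyond the scatter) when 4-chloro-3-nitrophenyl replaces 2-chloro-5-nitrophenyl, so the earlier step from compound 1 to compound 2 belongs to the particular 2-chloro-5-nitrophenyl group and not to chloronitrophenyl groups in general. Nothing given here explains either step.

Still open, going by these compounds, is which part of the 2-chloro-5-nitrophenyl group goes with the lower number of compound 1, the chlorine or the nitro group. A phenyl carrying an amine or a nitrile in place of that nitro group would bear on this question.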